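The source may report more compounds than this note shows. Statements on the series, on what has been measured and on what is new or still open speak of the compounds shown alone.

Of the compounds shown here, three have so far been measured in a functional assay on COLO 205 cells (Homo sapiens) for antiproliferative activity, read by MTT assay, with a stated time of 68 h; on this read-out higher numbers stand for weaker inhibition and lower numbers for stronger inhibition. Compound 1 `O=S(=O)(Nc1ccc(F)c(C#Cc2cnc3[nH]ncc3c2)c1F)c1ccccc1F` gives 534 nM. Compound 2 `O=S(=O)(Nc1ccc(F)c(C#Cc2cnc3[nH]ccc3c2)c1F)c1cccnc1` gives 1170 nM. Compound 3 `COc1n[nH]c2ncc(C#Cc3c(F)ccc(NS(=O)(=O)c4cccnc4)c3F)cc12` gives 89 nM, the lowest of the three numbers; its steps to compound 1 and to compound 2 both lie beyond the usual scatter, so compound 3 counts as the most potent of the set.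

Compound 4 `O=S(=O)(Nc1ccc(F)c(C#Cc2cnc3[nH]nc(-c4cccc(Cl)c4)c3c2)c1F)c1cccnc1` keeps the shared core of compound 3 and differs from it in one place: 3-chlorophenyl in place of methoxy on an aromatic carbon. Among the measured compounds shown here, no measured pair in this set shows this particular exchange, so the data at hand do not tell how the replacement of a small methoxy by a larger 3-chlorophenyl will play out. A step beyond the scatter is expected, more likely toward weaker inhibition than toward stronger, since the most potent compound measured carries the methoxy. In this assay the expected step is a 2.0-fold higher number from compound 3 to compound 4 (0.31 log units; beyond the scatter). Compound 4 is accordingly estimated at 180 nM, with a range from 45 nM to 700 nM.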

Compound 4, half-maximal inhibitory concentration: > 10000 nM
Compound 4: no number, only a limit; the forecaster's own chance of this, stated with the estimate: 3%; middle value at least 55-fold (1.74 log units) away from the limit.
By their numbers in this assay, from the lowest: compound 3; then compound 1; then compound 2. At a limit, above all of these: compound 4.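

Methoxy at this position of the shared core cannot simply be exchanged for a larger group that brings in a ring: in this assay, 3-chlorophenyl in place of methoxy gives an at least 110-fold higher number from compound 3 to compound 4 (2.05 log units; beyond the scatter). Among the compounds shown here, this is the first step in the set between two compounds that differ in one place, and it shows that a change at this position alone can move the read-out very far. The value of compound 4 is a limit and not a number, the only one among the compounds shown: the limit of > 10000 nM in this assay, at which 1 of the 4 values shown sits.

The compounds shown do not tell whether any aromatic ring at this position gives such a result, or whether it is specific to 3-chlorophenyl, as an unsubstituted phenyl could show. They also leave open how an amine or ethoxy would compare with methoxy here.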